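Trifluoromethyl in place of bromo: a small step expected

A few compounds are considered here, and "the series" means these few. Any claim that something is new, unique, unknown or untested is made for them only; others in the source may bear on it.

Three compounds share one core. In a functional assay on HBL-100 cells (Homo sapiens) for inhibition, read by sulforhodamine B assay, with a stated time of 48 h (a higher number here means a weaker inhibitor of growth, a lower number a stronger inhibitor of growth), compound 1 `COC(=O)[C@@]1(C)CCC=C2[C@@H]1CC[C@@H](C)[C@]2(C)Cc1c[nH]c2ccc(C)cc12` gives 18000 nM, compound 2 `COC(=O)[C@@]1(C)CCC=C2[C@@H]1CC[C@@H](C)[C@]2(C)Cc1c[nH]c2ccc(Br)cc12` gives 16000 nM, and compound 3 `COC(=O)[C@@]1(C)CCC=C2[C@@H]1CC[C@@H](C)[C@]2(C)Cc1c(C)[nH]c2ccc(Br)cc12` gives 15000 nM. Compound 3 has the lowest of the three numbers, yet all three lie within the scatter of one another, so none can be called the stronger inhibitor of growth. Compound 4 `COC(=O)[C@@]1(C)CCC=C2[C@@H]1CC[C@@H](C)[C@]2(C)Cc1c(C)[nH]c2ccc(C(F)(F)F)cc12` differs from compound 3 by one change: trifluoromethyl in place of bromo on an aromatic carbon. Among the compounds with values here, no measured step exchanges these two groups directly. The nearest guide is a 1.1-fold lower number from compound 1 to compound 2 (0.05 log units; within the scatter), also a swap of one group for another on an aromatic carbon, and a 1.1-fold lower number from compound 2 to compound 3 (0.03 log units; within the scatter) was just as small. A step within the scatter is therefore expected in this assay, no change at the digits printed from compound 3 to compound 4 (within the scatter). Compound 4 is expected to give 15000 nM, between 7000 nM and 35000 nM.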

Compound 4, concentration for 50% growth inhibition: 16000 nM
Beside the measured number, compound 4's estimate is 1.1-fold (0.03 log units) below it, within the range that was stated.
By their numbers in this assay, from the lowest: compounds 3, 2, 4 and 1 (each within the scatter of the next).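

In this assay, trifluoromethyl with its four heavy atoms replaces bromo with its one on this aromatic carbon, giving a 1.1-fold higher number from compound 3 to compound 4 (0.03 log units; within the scatter). Within the data shown here, this position had so far carried only methyl and bromo, and a group with more heavy atoms still produces no step that stands out from the scatter. No supporting data bear on this result.

Still open, as far as these compounds go, is whether an amine or a carboxylic acid on this carbon would move the number beyond the scatter. From the compounds shown here alone, whether a change elsewhere on the shared core would do so is also open.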